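A few compounds are considered here, and "the series" means these few. Any claim that something is new, unique, unknown or untested is made for them only; others in the source may bear on it.

Measured so far, in a physicochemical assay for lipophilicity, at pH 7.4; on this read-out lower numbers stand for lower lipophilicity and higher numbers for higher lipophilicity:

Compound 1 `CNC(=O)c1cc(C(=O)NC2CC2)cc2c1O[C@H](CF)[C@H]2c1ccccc1` gives 3.9.
Compound 2 `CNC(=O)c1cc(C(=O)NC)c2c(c1)[C@](C)(c1ccccc1)CO2` gives 3.4.
Compound 3 `CNC(=O)c1cc(C(=O)N[C@H]2[C@@H]3COC[C@@H]32)cc2c1OC[C@H]2c1ccc(F)cc1` gives 3.6.

Compound 2 stands at the low end of these three numbers. Compound 3 is its nearest neighbour, and the gap between them lies within the usual scatter, so the two cannot be set in order. Compound 1 is the furthest, and that gap lies beyond the scatter.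

Compound 4 `CNC(=O)c1cc(C(=O)N[C@H]2[C@@H]3COC[C@@H]32)cc2c1OC[C@@]2(C)c1ccccc1` is not yet measured in this assay. It differs from compound 2 in one place: a group of 6 heavy atoms (5 carbon, 1 oxygen; one three-membered non-aromatic ring of carbon only, one five-membered non-aromatic ring with 1 hetero atom) in place of one carbon atom, on an amide-type nitrogen. Compound 3 carries the same bicyclic amide and gives 3.6, a number not far from compound 2, but compound 3 also differs elsewhere, so no clean comparison of this change alone is available among the measured compounds.

On the size of the change, a group of six heavy atoms entering for one carbon, a modest rise in lipophilicity is expected, though it could fall within the scatter. For compound 4 the estimate is 3.8, with a range from 3.4 to 4.2. This estimate means an expected step of a number 0.40 log units higher from compound 2 to compound 4 (beyond the scatter).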

Compound 4, distribution coefficient: 3.7
Compound 4: middle estimate off by 0.10 log units, on the high side, within the range that was stated.
By their numbers in this assay, from the lowest: compounds 2, 3, 4 and 1 (each within the scatter of the next, the first and the last beyond it).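

In this assay, among the compounds shown here, the entry of the group of 6 heavy atoms in place of the methyl, on an amide-type nitrogen whose other neighbour is the carbonyl carbon, amounts to a number 0.30 log units higher from compound 2 to compound 4 (within the scatter) and so gives the first clean reading of this change at this position. For the compounds shown here, until now this group had been seen only in compound 3, which also differs from compound 2 elsewhere. The pair shows that this much larger group, with its two rings and one hydrogen-bond acceptor, can stand on this nitrogen without a difference that this read-out can separate from the scatter, and no measurement shown here offers an explanation for that result.

As far as these compounds go, this remains a single pair on a single core, so it is open whether the same exchange would give a similar step on the core of compound 1 or compound 3. It is equally open how this read-out would respond at this nitrogen to a group carrying an amine or a carboxylic acid, since every group shown here on this nitrogen carries no net charge.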